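Methyl to Methoxy Exchange in a Cytotoxicity Series

The source may hold more compounds than are shown below. What is called first, only, known or untested is meant among the compounds shown, and "the series" means these compounds.

Of the compounds shown here, three have been measured in a functional assay on KB cells (Homo sapiens) for cytotoxicity, read by MTT assay, with a stated time of 72 h; a higher number here means a weaker inhibitor, a lower number a stronger inhibitor. Compound 1 `Cc1cccc2cc3c(nc12)-c1nc2ccccc2n1C3` gives 20000 nM, and compound 3 `COc1cccc2cc3c(nc12)-c1nc2ccccc2n1C3`, which differs from it by methoxy in place of methyl on an aromatic carbon, gives 16900 nM; the step of a 1.2-fold lower number from compound 1 to compound 3 (0.07 log units; within the scatter) lies within the scatter. Compound 2 `Cc1ccc2cc3c(nc2c1)-c1nc2ccccc2n1C3` gives 75000 nM in this assay; it has the same atoms as compound 1, but the difference between the two cores is not broken down here. Compound 4 `COc1ccc2cc3c(nc2c1)-c1nc2ccccc2n1C3` is not yet measured and differs from compound 2 by methoxy in place of methyl on an aromatic carbon. This is the same kind of change as that between compound 1 and compound 3, though the place differs: there the carbon is ortho to a fused ring and meta to a fused ring, here meta to a fused ring and para to a fused ring. The expected step is a 1.2-fold lower number from compound 2 to compound 4 (0.08 log units; within the scatter), because the earlier step of a 1.2-fold lower number from compound 1 to compound 3 (0.07 log units; within the scatter) stayed within the scatter. Compound 4 is estimated at 62000 nM, between 30000 nM and 130000 nM.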

Compound 4, half-maximal inhibitory concentration: 40600 nM
Compound 4: the middle estimate sits 1.5-fold (0.18 log units) above what was measured, within the range that was stated.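

In this assay the exchange of methyl for methoxy on the core of compound 2 gives a 1.8-fold lower number from compound 2 to compound 4 (0.27 log units; within the scatter) and so stays within the scatter on this core too. Set beside the earlier step, the change shows no measurable difference between the two cores: the same change on two cores in this assay, a 1.2-fold lower number (0.07 log units; within the scatter) from compound 1 to compound 3 and a 1.8-fold lower number (0.27 log units; within the scatter) from compound 2 to compound 4, 1.6-fold (0.19 log units) apart, within the scatter of two such steps. This shows that the exchange carried over between these two cores without a detectable shift, but it does not show that the exchange has a real effect on either core, or that it would behave alike on any further core.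

The compounds shown leave open whether another group at these places, such as an amine, a carboxylic acid or a longer chain, would move the number beyond the scatter.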